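Replacing a pyrazole with a pyrimidine: an expected weaker binder

The source may hold more compounds than are shown below. What is called first, only, known or untested is meant among the compounds shown, and "the series" means these compounds.

Measured in an in vitro assay on BHK cells for displacement of a labelled ligand from Alpha-1A adrenergic receptor (Bos taurus), read by scintillation counting, with a stated time of 20 min; on this read-out lower numbers stand for stronger inhibition and higher numbers for weaker inhibition:
- compound 1 `CN1CCC(c2cn(-c3ccc(F)cc3)c3ccc(-c4ccnn4C)cc23)CC1`: 0.32 nM
- compound 2 `CN1CCC(c2cn(-c3ccncc3)c3ccc(-c4ccnn4C)cc23)CC1`: 19 nM
- compound 3 `CN1CCC(c2cn(-c3ccc(F)cc3)c3ccc(-c4ccncc4)cc23)CC1`: 10 nM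

Compound 2 gives the highest number of the three. Compound 3 lies within the scatter of it, whereas compound 1 stands far lower: a 59-fold higher number from compound 1 to compound 2 (1.77 log units; beyond the scatter). Compound 4 `CN1CCC(c2cn(-c3ccncc3)c3ccc(-c4cncnc4)cc23)CC1` differs from compound 2 by pyrimidin-5-yl in place of 1-methyl-1H-pyrazol-5-yl on an aromatic carbon. The measured step that bears on this change is the one on an aromatic carbon from compound 1 to compound 3, a 31-fold higher number from compound 1 to compound 3 (1.49 log units; beyond the scatter), where a six-membered ring with one hetero atom replaced the same pyrazole. Pyrimidin-5-yl is likewise a six-membered aromatic ring with two hetero atoms, so a large step in the same direction is expected in this assay: a 21-fold higher number from compound 2 to compound 4 (1.32 log units; beyond the scatter). Compound 4 is therefore estimated at 400 nM, with a range from 100 nM to 1600 nM.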

Compound 4, inhibition constant: 19 nM
Compound 4: the middle estimate sits 21-fold (1.32 log units) above what was measured; the whole stated range lies above it.
By their numbers in this assay, from the lowest: compound 1; then compounds 3, 2 and 4 (each within the scatter of the next).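

In this assay the exchange of 1-methyl-1H-pyrazol-5-yl for pyrimidin-5-yl gives no change at the digits printed from compound 2 to compound 4 (within the scatter) with pyridin-4-yl on the aromatic nitrogen. A six-membered ring on this aromatic carbon therefore need not weaken binding, although a 31-fold higher number from compound 1 to compound 3 (1.49 log units; beyond the scatter) stands as a large step for pyridin-4-yl with 4-fluorophenyl on the nitrogen. No measurement shown here accounts for the difference between these two steps. Still open, as far as these compounds go, is how pyrimidin-5-yl reads with 4-fluorophenyl on the nitrogen, and how an amine or a carboxylic acid on this aromatic carbon would read.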